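The compounds below may be only part of what the source reports. "The series", "measured", "known", "first", "only" and "open" are said of these compounds alone.

Compound 1 `CCCCCCCCCNC(=O)N(Cc1cc(OC)ccc1OC)n1cnnc1` gives > 50000 nM in a functional assay on MDA-MB-231 cells (Homo sapiens) for cytotoxicity, read by MTT assay, with a stated time of 48 h (a lower number here means a stronger inhibitor, a higher number a weaker inhibitor), which is a limit of the assay and not a number.
Compound 2 `O=C(Nc1ccccc1)N(Cc1ccccn1)n1cnnc1` gives > 50000 nM in this assay, again a limit.
Compound 3 `COc1ccc(OC)c(CN(C(=O)Nc2ccc(C)cc2)n2cnnc2)c1` gives > 50000 nM in this assay, also a limit.

All three measured compounds sit at the same point, (the limit of > 50000 nM in this assay, at which 3 of the 3 values shown sit), so nothing in this set resolves a number. Going by the values given here, compound 3 therefore stands only at a limit in this assay, with no measured compound placed anywhere else. Among the compounds with values here, the single step between measured compounds, a step that the two limits leave unreadable from compound 1 to compound 3, is likewise unreadable, since both ends are limits; its size and direction cannot be drawn from the data.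

Compound 4 `COc1ccc(OC)c(CN(C(=O)NC2CCCCC2)n2cnnc2)c1` differs from compound 3 by cyclohexyl in place of 4-methylphenyl on an amide-type nitrogen. Within the data shown here, no measured step bears readably on this change, and the earlier step between compound 1 and compound 3 gives no guidance on its size.

For compound 4 the step that the limit leaves unreadable from compound 3 to compound 4 in this assay is expected to remain unreadable, with the value most likely again at the limit. The estimate for compound 4 in this assay is 80000 nM, within a range of 20000 nM to 300000 nM, and it is expected that this measurement too will be reported only as a limit.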

Compound 4, half-maximal inhibitory concentration: > 50000 nM
Compound 4 ended at the assay's limit; the forecaster's own chance of this, stated with the estimate: 85%; the middle value is on the limit's open side.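

No step can be read from compound 1 to compound 4 or from compound 3 to compound 4, since both ends of each step are limits and not numbers: the limit of > 50000 nM in this assay, at which 4 of the 4 values shown sit. The compounds shown leave open whether any change to this series gives a measurable value in this assay.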